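The compounds below may be only part of what the source reports. "The series", "measured", "known", "first", "only" and "open" are said of these compounds alone.

Measured so far:
compound 1 `O=C(Nc1cccc(-n2cc(-c3ccncc3)c(-c3cc(O)cc(Cl)c3)n2)c1)Nc1ccc(Cl)c(Cl)c1`: 100%
compound 2 `COc1cc(Cl)cc(-c2nn(-c3cccc(NC(=O)Nc4ccc(Cl)c(C(F)(F)F)c4)c3)cc2-c2ccncc2)c1`: 62%

In a functional assay on OVCAR-4 cells (Homo sapiens) for inhibition, read by sulforhodamine B assay, with a stated time of 48 h, tested at 1 uM (a higher number here means a weaker effect of the compound at the concentration tested, a lower number a stronger effect), compound 1 gives 100%, and compound 2 gives 62%. Compound 2 stands lowest of the two numbers; the nearest, compound 1, sits higher by a gap beyond the scatter, so compound 2 is the stronger of the pair at the tested concentration. Among the compounds with values here, no pair of measured compounds differs in one place only, so no measured step can be read across the set.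

Compound 3 `COc1cc(Cl)cc(-c2nn(-c3cccc(NC(=O)Nc4ccc(Cl)c(Cl)c4)c3)cc2-c2ccncc2)c1` differs from compound 2 in a single place: chloro in place of trifluoromethyl on an aromatic carbon. Within the data shown here, no measured pair shows this change, so the expectation rests on compound 2 alone. The step from compound 2 to compound 3 is expected to be small, a number 6 percentage points higher from compound 2 to compound 3 (within the scatter), towards a slightly higher number, and not beyond the scatter. Compound 3 is estimated at 68%, with a range from 48% to 92%.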

Compound 3, a percentage reported as activity, at one concentration (the size of the read-out at that concentration, not a potency): 83%
Beside the measured number, compound 3's estimate is 15 percentage points below it; measured number inside the range.
By their numbers in this assay, from the lowest: compound 2; then compound 3; then compound 1.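

In this assay the aromatic carbon ortho to a chloro group responds to the group it carries: chloro in place of trifluoromethyl gives a number 21 percentage points higher from compound 2 to compound 3 (beyond the scatter) and so separates 4-chloro-3-(trifluoromethyl)phenyl from 3,4-dichlorophenyl at the concentration tested. Within the data shown here, with 3,4-dichlorophenyl held constant, methyl in place of hydrogen on an oxygen on an aromatic ring gives a number 17 percentage points lower from compound 1 to compound 3 (beyond the scatter) and thus provides the first single-change reading at that oxygen. No measured property bears on either step.

On these data alone, how other groups on the same aromatic carbon, such as bromo or nitrile, would read remains open, as does the effect of an ethyl group or a longer chain on the oxygen. As far as these compounds go, it is also open whether trifluoromethyl and chloro would differ in the same direction with the free hydroxyl of compound 1 in place.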